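Chloro to fluoro on compound 2

A few compounds are considered here, and "the series" means these few. Any claim that something is new, unique, unknown or untested is made for them only; others in the source may bear on it.

Values from a functional assay on SW-620 cells (Homo sapiens) for inhibition (on this read-out lower numbers stand for stronger inhibition and higher numbers for weaker inhibition), follow
Compound 1 `COc1ccc(-c2cc(-c3cc(OC)c(OC)c(OC)c3)[nH]n2)cc1` gives 5150 nM; 3410 nM (2 entries)
Compound 2 `COc1cc(-c2cc(-c3ccc(Cl)cc3)[nH]n2)cc(OC)c1OC` gives 4960 nM

Compound 2 has one number (4960 nM) and one further entry without a single number. Compound 3 `COc1cc(-c2cc(-c3ccc(F)cc3)[nH]n2)cc(OC)c1OC` differs from compound 2 by fluoro in place of chloro on an aromatic carbon (fluoro in place of chloro on an aromatic carbon, para to a large group). For the measured compounds named here, no measured pair tests this change, so in this assay no shift beyond the scatter is expected, in either direction. The estimated change is a 1.1-fold higher number from compound 2 to compound 3 (0.04 log units; within the scatter) (expected to stay small). Compound 3 is expected at 5500 nM (estimated range 2500 nM to 12000 nM).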

Compound 3, half-maximal inhibitory concentration: 5900 nM
Compound 3: middle estimate off by 1.1-fold (0.03 log units), on the low side; low and high end bracket the measured number.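

In this assay, going from 4-chlorophenyl to 4-fluorophenyl gives a 1.2-fold higher number from compound 2 to compound 3 (0.08 log units; within the scatter), so this read-out does not tell fluoro and chloro apart at this position. The step is no larger than the spread between repeat entries of a single compound: the several entries of compound 1 in this assay, 5150 nM; 3410 nM (2 entries)

The reading covers this one exchange on an aromatic carbon and says nothing about other kinds of group there. Going by these compounds, whether an amine or a carboxylic acid at the same place would move the number beyond the scatter remains open.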